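A few compounds are considered here, and "the series" means these few. Any claim that something is new, unique, unknown or untested is made for them only; others in the source may bear on it.

Among the compounds with values here, compound 1, `c1ccc2c(c1)CN[C@@H](CN(CC[C@H]1CCCNC1)[C@H]1CCCc3cccnc31)C2`, stands at the strong end of the three compounds measured so far: in a functional assay on CCRF-CEM cells for antagonist activity at C-X-C chemokine receptor type 4 (Homo sapiens), read by calcium flux, with stated times of 25 min and 90 s (on this read-out higher numbers stand for weaker inhibition and lower numbers for stronger inhibition), compound 1 gives 16 nM, the lowest number of the set. Compound 2, `c1cnc(CN(CCCN2CCNCC2)[C@H]2CCCc3cccnc32)nc1`, gives 4320 nM in this assay, and compound 3, `c1cnc2c(c1)CN[C@H](CN(CCCN1CCNCC1)[C@H]1CCCc3cccnc31)C2`, gives 2640 nM. Within the data shown here, the one single-point step among them, a 1.6-fold lower number from compound 2 to compound 3 (0.21 log units; within the scatter), concerns the exchange of an aromatic substituent on the chain carbon bound to an amine nitrogen and lies within the scatter, so it says little about the change now in question.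

Compound 4, `NC(=O)N1CCN(CCCN(C[C@H]2Cc3ccccc3CN2)[C@H]2CCCc3cccnc32)CC1`, differs from compound 1 in one place: (4-carbamoylpiperazin-1-yl)methyl in place of piperidin-3-yl on a saturated chain carbon, two bonds along the chain from an amine nitrogen. Among the measured compounds shown here, no measured pair isolates this change. For the measured compounds named here, the only guide is that compound 3, which carries a piperazine on its chain, sits far above compound 1, but compound 3 also differs from compound 1 in its core, so that gap cannot be assigned to the chain alone. Since the move toward a chain-borne piperazine is not shown on its own, the expectation for compound 4 is a weaker number than compound 1, but with wide uncertainty: compound 4 is expected to give 120 nM, between 20 nM and 900 nM, a step of a 7.5-fold higher number from compound 1 to compound 4 (0.88 log units; beyond the scatter).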

Compound 4, half-maximal inhibitory concentration: 959 nM
Compound 4: the middle estimate sits 8.0-fold (0.90 log units) below what was measured; the measured number lies above the stated range.
By their numbers in this assay, from the lowest: compound 1; then compound 4; then compounds 3 and 2 (each within the scatter of the next).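

In this assay, putting (4-carbamoylpiperazin-1-yl)methyl in place of piperidin-3-yl on a saturated chain carbon, two bonds along the chain from an amine nitrogen, gives a 60-fold higher number from compound 1 to compound 4 (1.78 log units; beyond the scatter) and is a large step, so with the rest of compound 1 held fixed, the group at this place has a strong bearing on the inhibition read here. Within the data shown here, the earlier compounds could not show this, as their only single-point step concerned a different exchange and stayed within the scatter. No measurement at hand accounts for the size of this step.

The exchange alters several things at once: the ring gains a second hetero atom, a carbamoyl group appears, a methyl link is added and the defined stereocentre of the piperidin-3-yl group is lost, so the compounds shown cannot say which of these carries the change. On these data alone, it remains open how a piperazin-1-ylmethyl group without the carbamoyl, or a piperidin-3-ylmethyl group, would read at this place, and either would help to separate the ring from the carbamoyl and the link.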